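The source may report more compounds than this note shows. Statements on the series, on what has been measured and on what is new or still open speak of the compounds shown alone.

Measured compounds:
Compound 1 `O=C1C(=O)N(CN(c2ccccc2)c2ccccc2)c2cccc(Cl)c21`: 77200 nM
Compound 2 `Cc1ccc2nc(/N=C3\C(=O)N(CN(c4ccccc4)c4ccccc4)c4cccc(Br)c43)sc2c1`: 67900 nM
Compound 3 `Cc1ccc2nc(/N=C3\C(=O)N(CN(c4ccccc4)c4ccccc4)c4cccc(Cl)c43)sc2c1`: 70000 nM

All three numbers come from an ADME assay on MCF-10A cells (Homo sapiens) for cytotoxicity, read by sulforhodamine B assay, with a stated time of 48 h; a higher number here means a weaker inhibitor of growth, a lower number a stronger inhibitor of growth. Compound 3 gives 70000 nM, the second highest of the three, and its nearest neighbour is compound 2 with 67900 nM. Compound 1 gives 77200 nM. Every gap among these three is within the usual scatter, so no compound can be called stronger or weaker than another here.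

Compound 4 `Cc1ccc2nc(/N=C3\C(=O)N(CN(c4ccccc4)c4ccccc4)c4ccccc43)sc2c1` has not yet been measured. It differs from compound 3 by a single change: hydrogen in place of chloro on an aromatic carbon. Among the compounds with values here, one measured step bears on this position: a 1.0-fold higher number from compound 2 to compound 3 (0.01 log units; within the scatter). Exchanging one halogen for another there left the number unchanged, and compound 1, which also carries chloro, sits within the scatter of compounds 2 and 3 despite differing elsewhere. Removing the chloro altogether is therefore expected to produce no step beyond the scatter, and the expected step is a 1.0-fold higher number from compound 3 to compound 4 (0.01 log units; within the scatter). Compound 4 is estimated at 72000 nM. For compound 4 the expected range runs from 38000 nM to 140000 nM.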

Compound 4, concentration for 50% growth inhibition: 34000 nM
The estimate for compound 4 lay 2.1-fold (0.33 log units) above the measured number, and the stated range ends above it.
By their numbers in this assay, from the lowest: compounds 4, 2, 3 and 1 (each within the scatter of the next, the first and the last beyond it).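

In this assay this aromatic carbon no longer looks indifferent to what it carries: exchanging one halogen for another changed nothing measurable (a 1.0-fold higher number from compound 2 to compound 3 (0.01 log units; within the scatter)), but removing the chloro altogether gives a modest step (a 2.1-fold lower number from compound 3 to compound 4 (0.31 log units; beyond the scatter)). Removing the bromo gives a step of almost the same size that still falls within the scatter (a 2.0-fold lower number from compound 2 to compound 4 (0.30 log units; within the scatter)), so the case for a difference between halogen and hydrogen here rests on one small step. Nothing measured here gives a reason for that step.

Going by these compounds, whether another group on this carbon, such as fluoro, methoxy or an amine, would behave like the halogens or like hydrogen remains open. So does whether a larger group, such as a longer alkyl chain, would move the number further.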